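Adding a Second Chloro to Compound 3

This account rests on a few compounds, and the source may have more. Where it says the series, first, only, none or still open, it means among the compounds named here.

Values in a functional assay on MOLT-4 cells (Homo sapiens) for antiproliferative activity, with a stated time of 48 h; a higher number here means a weaker inhibitor, a lower number a stronger inhibitor:
- compound 1 `C=C(Br)C(=O)Nc1ccc(/C=C/C(=O)c2ccccc2)cc1`: 3100 nM
- compound 2 `C=C(Br)C(=O)Nc1ccc(/C=C/C(=O)c2ccc(F)cc2)cc1`: 660 nM
- compound 3 `C=C(Br)C(=O)Nc1ccc(/C=C/C(=O)c2ccc(Cl)cc2)cc1`: 810 nM

In this assay compound 3 gives 810 nM. The comparison with its nearest neighbour, a 1.2-fold higher number from compound 2 to compound 3 (0.09 log units; within the scatter), shows that these two compounds cannot be told apart. Compound 1 stands well apart, as the step of a 3.8-fold lower number from compound 1 to compound 3 (0.58 log units; beyond the scatter) shows.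

Compound 4 `C=C(Br)C(=O)Nc1ccc(/C=C/C(=O)c2ccc(Cl)c(Cl)c2)cc1` is the next structure to be tested. It differs from compound 3 by chloro in place of hydrogen on an aromatic carbon, and the change reads 4-chlorophenyl to 3,4-dichlorophenyl. The new chloro sits ortho to a chloro group.

Two measured steps are of a similar kind, each adding one halogen where there was none: a 4.7-fold lower number from compound 1 to compound 2 (0.67 log units; beyond the scatter) and a 3.8-fold lower number from compound 1 to compound 3 (0.58 log units; beyond the scatter). Both are modest and point to a lower number. Among the compounds with values here, both, however, start from a ring without a halogen, and no measured compound carries two halogens, so they are only an imperfect guide. A modest move in the same direction is therefore the likeliest outcome, although a change within the scatter remains possible. The expected step is a 1.7-fold lower number from compound 3 to compound 4 (0.23 log units; within the scatter). The estimated value for compound 4 is 480 nM, with an expected range of 200 nM to 1100 nM.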

Compound 4, half-maximal inhibitory concentration: 1800 nM
Beside the measured number, compound 4's estimate is 3.8-fold (0.57 log units) below it; measured number above the stated range.
By their numbers in this assay, from the lowest: compounds 2 and 3 (each within the scatter of the next); then compounds 4 and 1 (each within the scatter of the next).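

In this assay, chloro ortho to a chloro group does not repeat the drop in number seen when the first halogen entered the ring of compound 1: a 2.2-fold higher number from compound 3 to compound 4 (0.35 log units; beyond the scatter) runs the opposite way, so a second halogen here cannot be read as a further step of the same kind. The 3,4-dichlorophenyl group also loses the advantage that 4-fluorophenyl holds over phenyl, with a 2.7-fold higher number from compound 2 to compound 4 (0.44 log units; beyond the scatter), while a 1.7-fold lower number from compound 1 to compound 4 (0.24 log units; within the scatter) means that compound 4 cannot be told apart from compound 1. No measurement at hand accounts for this reversal.

The compounds shown leave open whether the rise belongs to chloro itself or to any group at this place, which a fluoro, a methoxy or an amine ortho to the chloro group would help separate. Also open, as far as these compounds go, is whether the step depends on the existing chloro group, which the same change on the 4-fluorophenyl ring of compound 2 would test.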